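The compounds below may be only part of what the source reports. "The series", "measured", "known", "first", "only" and "open" are said of these compounds alone.

Measured so far:
- compound 1 `CCOc1cc(NC(=O)NCc2cc(C)c(-c3cn(C)nc3C(F)(F)F)nn2)cc(C)n1`: < 58.4 mL/min/kg
- compound 2 `COCCOc1cc(NC(=O)NCc2cc(C)c(-c3cn(C)nc3C(F)(F)F)nn2)cc(Cl)n1`: 317 mL/min/kg
- compound 3 `CCOc1nc(Cl)cc(NC(=O)NCc2cc(C)c(-c3cn(C)nc3C(F)(F)F)nn2)c1C`: < 534 mL/min/kg

In an ADME assay on microsomes from liver (Mus musculus) for metabolic stability, read by LC-MS, with a stated time of 4 h, tested at 1 uM (a lower number here means slower removal, a higher number faster removal of the compound), compound 1 gives < 58.4 mL/min/kg, which is a limit of the assay and not a number. Compound 3 also gives only a limit, < 534 mL/min/kg. Compound 2 alone has a true number, 317 mL/min/kg.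

Compound 4 `CCOc1nc(C)cc(NC(=O)NCc2cc(C)c(-c3cn(C)nc3C(F)(F)F)nn2)c1C#N` differs from compound 1 by one change: cyano in place of hydrogen on an aromatic carbon. Among the compounds with values here, the only measured step, a step that the two limits leave unreadable from compound 1 to compound 3, involves other groups and has no readable size, and no measured compound carries a cyano. The expectation therefore rests on the limit of compound 1, < 58.4 mL/min/kg. No shift beyond the scatter is expected, so the expected step is an at least 1.0-fold higher number from compound 1 to compound 4 (0.01 log units; that floor lies within the scatter). For compound 4 the estimate is 60 mL/min/kg, with an expected range of 20 mL/min/kg to 250 mL/min/kg.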

Compound 4, clearance: 2270 mL/min/kg
Compound 4: middle estimate off by 38-fold (1.58 log units), on the low side; the measured number lies above the stated range.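

In this assay, cyano on this aromatic carbon, ortho to a large group and ortho to an ethoxy group, proves far from a neutral change: the swap gives an at least 38-fold higher number from compound 1 to compound 4 (1.58 log units; beyond the scatter). Within the data shown here, this is the first readable step, as the earlier step between compound 1 and compound 3 cannot be read. The size is only a floor because compound 1 has a limit and not a number: the limit of < 58.4 mL/min/kg in this assay, at which 1 of the 4 values shown sits.

The compounds shown leave open whether the rise belongs to cyano alone. A methyl group or a fluorine atom on this same carbon could separate the two possibilities.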